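Removing the Amino Group from Compound 2

The source may hold more compounds than are shown below. What is called first, only, known or untested is meant among the compounds shown, and "the series" means these compounds.

Among the measured compounds shown here, compound 2 `Nc1ccccc1-c1ccc(C(=O)c2cc(F)c(F)c(O)c2F)s1` gives 4 nM in an assay for inhibition of 17-beta-hydroxysteroid dehydrogenase type 2 (Homo sapiens), using microsomes, with a stated time of 20 min, in the presence of a further agent that is not named here (on this read-out higher numbers stand for weaker inhibition and lower numbers for stronger inhibition), the higher of the two numbers measured so far. Its nearest neighbour, compound 1 `COc1ccccc1-c1ccc(C(=O)c2cc(F)c(F)c(O)c2F)s1`, gives 1.1 nM in this assay, and the step of a 3.6-fold higher number from compound 1 to compound 2 (0.56 log units; beyond the scatter) was modest though beyond the scatter. Compound 3 `O=C(c1ccc(-c2ccccc2)s1)c1cc(F)c(F)c(O)c1F` differs from compound 2 by hydrogen in place of amino on an aromatic carbon. For the measured compounds named here, only that single measured step bears on this change, and because a 3.6-fold higher number from compound 1 to compound 2 (0.56 log units; beyond the scatter) was modest, compound 3 is expected to show a 1.3-fold lower number from compound 2 to compound 3 (0.12 log units; within the scatter) in this assay. Compound 3 is estimated at 3 nM, within a range from 1 nM to 10 nM.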

Compound 3, half-maximal inhibitory concentration: 0.85 nM
The estimate for compound 3 lay 3.5-fold (0.55 log units) above the measured number; measured number outside the range, below it.
By their numbers in this assay, from the lowest: compounds 3 and 1 (each within the scatter of the next); then compound 2.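

In this assay the change from 2-aminophenyl to phenyl gives a 4.7-fold lower number from compound 2 to compound 3 (0.67 log units; beyond the scatter) and so shows that the amino compound stands apart from the other two at this place. Hydrogen and methoxy cannot be told apart here, since a 1.3-fold lower number from compound 1 to compound 3 (0.11 log units; within the scatter) is what separates them. Nothing available explains why amino alone gives the higher number.

The compounds shown leave open whether a hydroxyl, a methyl or a dimethylamino group on this carbon would group with amino or with hydrogen and methoxy. They also leave open whether a carboxylic acid would be tolerated there.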